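This account rests on a few compounds, and the source may have more. Where it says the series, first, only, none or still open, it means among the compounds named here.

Among the measured compounds shown here, in a functional assay on HEK293 cells for agonist activity at D(4) dopamine receptor (Homo sapiens), read by FLIPR (a lower number here means that less compound is needed, a higher number that more compound is needed for the effect), compound 1, whose structure is `CCc1cccc(NC(=O)CN2CCC(c3cccc[n+]3[O-])CC2)c1`, gives 95 nM, the highest of the three numbers measured so far. Compound 2, built as `C=Cc1cccc(C(=O)NCN2CCC(c3cccc[n+]3[O-])CC2)c1`, gives 68 nM in this assay, a number that sits within the usual scatter of compound 1. Compound 3, with the structure `Cc1cccc(NC(=O)CN2CCC(c3ccc(O)cn3)CC2)c1`, gives 3.8 nM in this assay, a number well beyond that scatter from compound 1. Compound 4, drawn as `Cc1ccc(Cl)cc1NC(=O)CN1CCC(c2cccc[n+]2[O-])CC1`, has not yet been measured. Compared with compound 1 it carries 5-chloro-2-methylphenyl in place of 3-ethylphenyl on an amide-type nitrogen. For the measured compounds named here, no measured pair isolates this change, so the step of a 1.1-fold higher number from compound 1 to compound 4 (0.02 log units; within the scatter) is expected to stay within the scatter. Compound 4 is estimated at 100 nM in this assay, plausibly between 30 nM and 330 nM.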

Compound 4, half-maximal effective concentration: 126 nM
Compound 4: middle estimate off by 1.3-fold (0.10 log units), on the low side, within the range that was stated.
By their numbers in this assay, from the lowest: compound 3; then compounds 2, 1 and 4 (each within the scatter of the next).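

In this assay, replacing 3-ethylphenyl with 5-chloro-2-methylphenyl on the amide-type nitrogen gives a 1.3-fold higher number from compound 1 to compound 4 (0.12 log units; within the scatter) and leaves the number within the scatter. This position therefore accepts two differently substituted phenyl groups, one carrying chlorine, with no measurable difference. Nothing available explains why these two groups read alike.

From the compounds shown here alone, the chlorine and the methyl of compound 4 are not separated here, so the share of each remains open. Also open, going by these compounds, is how a phenyl ring bearing an amine or a carboxylic acid at this position would read.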